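The compounds below may be only part of what the source reports. "The series", "measured", "known", "first", "only" and "open" are said of these compounds alone.

Three compounds share one core and differ only in the group on an amine nitrogen in a ring. Compound 1 `Cc1ccc2c(NCc3ccc(NC(=O)C4CCN(C5CCCCC5)CC4)cc3)nc(N(C)C)nc2c1` carries cyclohexyl there; in a functional assay on SV5A8 cells (Homo sapiens) for cytotoxicity (on this read-out higher numbers stand for weaker inhibition and lower numbers for stronger inhibition), compound 1 reaches only the limit > 8320 nM. Compound 2 `Cc1ccc2c(NCc3ccc(NC(=O)C4CCN(CC5CCNCC5)CC4)cc3)nc(N(C)C)nc2c1` carries (piperidin-4-yl)methyl, and in this assay compound 2 likewise gives only the limit > 8070 nM. Compound 3 `Cc1ccc2c(NCc3ccc(NC(=O)C4CCN(C(=O)OC(C)(C)C)CC4)cc3)nc(N(C)C)nc2c1` carries tert-butoxycarbonyl, and in this assay compound 3 also stops at the limit > 4820 nM. Compound 3 thus stands among three values that are all limits, so no ordering among them can be read. The steps a step that the two limits leave unreadable from compound 1 to compound 3 and a step that the two limits leave unreadable from compound 2 to compound 3 are the ones that bear on the present change, and both are unreadable because every value involved is a limit, as the limit of > 4820 nM in this assay, at which 1 of the 3 values shown sits, the limit of > 8070 nM in this assay, at which 1 of the 3 values shown sits, and the limit of > 8320 nM in this assay, at which 1 of the 3 values shown sits, show.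

Compound 4 `Cc1ccc2c(NCc3ccc(NC(=O)C4CCN(Cc5ccc(Cl)cc5)CC4)cc3)nc(N(C)C)nc2c1` is the next member. 4-chlorobenzyl in place of tert-butoxycarbonyl on an amine nitrogen in a ring With only limits behind it, the step in this assay cannot be sized, and the most likely outcome is another limit. Compound 4 is therefore estimated at about 9000 nM in this assay, within 3000 nM to 30000 nM. This estimate amounts to an expected step that the limit leaves unreadable from compound 3 to compound 4.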

Compound 4, half-maximal inhibitory concentration: > 3180 nM
Compound 4: no number, only a limit (the forecaster's own chance of this, stated with the estimate: 75%); the middle value lies beyond the limit too.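

In this assay compound 4 gives only a limit, > 3180 nM. Its steps from compound 1, compound 2 and compound 3 cannot be read. The compounds shown leave open how the four groups on the amine nitrogen in a ring rank against one another in this assay.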